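A few compounds are considered here, and "the series" means these few. Any claim that something is new, unique, unknown or untested is made for them only; others in the source may bear on it.

Measured in a functional assay on MCF7 cells (Homo sapiens) for cytotoxicity, read by sulforhodamine B assay; on this read-out lower numbers stand for stronger inhibition of growth and higher numbers for weaker inhibition of growth:
- Compound 1 `CC1=CC[C@@H]([C@@](C)(O)CCCC(C)(C)NC(=S)N/N=C\c2ccccc2)CC1`: 28700 nM
- Compound 2 `COc1ccc(/C=N\NC(=S)NC(C)(C)CCC[C@](C)(O)[C@@H]2CC=C(C)CC2)cc1`: 94900 nM
- Compound 3 `CC1=CC[C@@H]([C@@](C)(O)CCCC(C)(C)NC(=S)N/N=C\c2ccccc2Cl)CC1`: > 100000 nM

The entry for compound 3 needs care. As far as these compounds go, compound 3 gives > 100000 nM, which is a limit of the assay and not a number, so its true value is unknown.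

Compound 4 `CC1=CC[C@@H]([C@@](C)(O)CCCC(C)(C)NC(=S)N/N=C\c2cccc(Cl)c2)CC1` has the same atoms joined differently, with 3-chlorophenyl in place of 2-chlorophenyl on a carbon with a double bond to nitrogen.

Among the compounds with values here, two measured steps bear on this. Adding a group to the aromatic ring of compound 1 raised the number both times: an at least 3.4-fold higher number from compound 1 to compound 3 (0.54 log units; beyond the scatter) with chloro and a 3.3-fold higher number from compound 1 to compound 2 (0.52 log units; beyond the scatter) with methoxy. The third step, an at least 1.0-fold higher number from compound 2 to compound 3 (0.02 log units; that floor lies within the scatter), says little, since its floor lies within the scatter. Compound 4 also carries a chloro group, so its number is expected to stay above that of compound 1 and near the top of this assay.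

The expected change is modest and downward, or none that can be seen: an at least 1.5-fold lower number from compound 3 to compound 4 (0.18 log units; that floor lies within the scatter). For compound 4 the estimated value is 65000 nM, with an expected range of 27000 nM to 100000 nM.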

Compound 4, concentration for total growth inhibition: 19500 nM
Beside the measured number, compound 4's estimate is 3.3-fold (0.52 log units) above it; measured number outside the range, below it.
By their numbers in this assay, from the lowest: compounds 4 and 1 (each within the scatter of the next); then compound 2. At a limit, above all of these: compound 3.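

In this assay, moving the chlorine around the ring gives an at least 5.1-fold lower number from compound 3 to compound 4 (0.70 log units; beyond the scatter), so where the chloro group sits matters, not just its presence. For compound 3 this comparison rests on a limit and not a number: the limit of > 100000 nM in this assay, at which 1 of the 4 values shown sits. The earlier picture of ring groups raising the number does not hold for 3-chlorophenyl: the change from the methoxy compound gives a 4.9-fold lower number from compound 2 to compound 4 (0.69 log units; beyond the scatter), while adding the chloro group to the unsubstituted ring gives a 1.5-fold lower number from compound 1 to compound 4 (0.17 log units; within the scatter), so here the group brings no change beyond the scatter.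

As far as these compounds go, it remains open whether a 4-chlorophenyl group would read like the 3-chlorophenyl or the 2-chlorophenyl group. A 3-methoxyphenyl group would help show whether the effect of ring position extends beyond chloro.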